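Changing One Aromatic Group in a Growth-Inhibiting Series

The source may hold more compounds than are shown below. What is called first, only, known or untested is meant among the compounds shown, and "the series" means these compounds.

Measured in a functional assay on SK-OV-3 cells (Homo sapiens) for cytotoxicity; on this read-out higher numbers stand for weaker inhibition of growth and lower numbers for stronger inhibition of growth:
- Compound 1 `COc1ccc(C2=C(c3cc(OC)c(OC)c(OC)c3)CC3CCCN3C2=O)cc1O`: > 100000 nM
- Compound 2 `CSc1ccc(C2=C(c3ccc(C)c(C)c3)C(=O)N3CCCC3C2)cc1`: 300 nM
- Compound 3 `CSc1ccc(C2=C(c3ccc(F)c(C)c3)C(=O)N3CCCC3C2)cc1`: 300 nM

Compound 1 reads > 100000 nM, which is a limit of the assay and not a number. the limit of > 100000 nM in this assay, at which 1 of the 3 values shown sits. It differs from the other two in more than one place, so it offers no clean single comparison here.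

Compound 3 gives 300 nM, level with compound 2 at 300 nM. The next compound, compound 4 `CSc1ccc(C2=C(c3ccc(Br)cc3)C(=O)N3CCCC3C2)cc1`, has 4-bromophenyl in place of 4-fluoro-3-methylphenyl on a double-bonded ring carbon. The 4-(methylsulfanyl)phenyl group stays as it is.

Among the compounds with values here, only one measured step touches this aromatic group: no change at the digits printed from compound 2 to compound 3 (within the scatter), with fluoro in place of methyl on an aromatic carbon. Within the data shown here, that step kept the methyl found in 4-fluoro-3-methylphenyl, whereas compound 4 has no such methyl, and no measured pair shows what losing it does. Bromine has also not been measured in this series. With that single step as a guide, only a modest change is expected in this assay, and its direction is uncertain, with slightly weaker inhibition of growth a little more likely.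

The expected change is a 1.3-fold higher number from compound 3 to compound 4 (0.12 log units; within the scatter).

Compound 4 is estimated at 400 nM, with an expected range of 120 nM to 1500 nM.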

Compound 4, concentration for 50% growth inhibition: 9000 nM
Beside the measured number, compound 4's estimate is 23-fold (1.35 log units) below it; the measured number lies above the stated range.
By their numbers in this assay, from the lowest: compounds 2 and 3 (each within the scatter of the next); then compound 4. At a limit, above all of these: compound 1.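

In this assay, within the data shown here, this position proves far more sensitive than the earlier compounds suggested: a 30-fold higher number from compound 3 to compound 4 (1.48 log units; beyond the scatter), and there is a 30-fold higher number from compound 2 to compound 4 (1.48 log units; beyond the scatter). Among these compounds, the only earlier step here, no change at the digits printed from compound 2 to compound 3 (within the scatter), made the group look freely exchangeable, but that step joined two rings that both carry a methyl, 3,4-dimethylphenyl and 4-fluoro-3-methylphenyl, and the tolerance it showed does not extend to 4-bromophenyl. No measurement at hand accounts for the size of this rise.

Compound 4 differs from compound 2 and compound 3 both in lacking the methyl and in carrying bromine, so the compounds shown cannot tell which of the two changes produces the much higher number. A 4-bromo-3-methylphenyl group in this place would keep the methyl alongside the bromine, and a 4-fluorophenyl group would remove the methyl while keeping the fluorine, so the pair would separate the two changes.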